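This account rests on a few compounds, and the source may have more. Where it says the series, first, only, none or still open, it means among the compounds named here.

Compound 1 `O=C1OC(c2ccc(Cl)cc2)=C/C1=C\c1ccccc1`: 18.9%
Compound 2 `O=C1OC(c2ccc(Cl)cc2)=C/C1=C\c1ccccc1Cl`: 62.7%
Compound 3 `O=C1OC(c2ccc(Cl)cc2)=C/C1=C\c1ccc(Cl)cc1`: 40%

In a functional assay on the whole organism (strain Wistar) for inhibition, with Rattus norvegicus as the target, with stated times of 30 min and 2 h, at a dose of 20 mg/kg by the oral route (on this read-out lower numbers stand for less inhibition and higher numbers for more inhibition at the one dose given (going by the name of the read-out)), compound 2 stands highest of the three measured compounds. The nearest of the others is reached by a number 22.7 percentage points lower from compound 2 to compound 3 (beyond the scatter), and the furthest by the reverse of a number 43.8 percentage points higher from compound 1 to compound 2 (beyond the scatter), both steps lying beyond the scatter.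

Compound 4 `O=C1OC(c2ccc(Cl)cc2)=C/C1=C\c1ccccc1[N+](=O)[O-]` is not yet measured. Its change from compound 2 is nitro in place of chloro on an aromatic carbon. Among the measured compounds shown here, two measured steps bear on it: a number 43.8 percentage points higher from compound 1 to compound 2 (beyond the scatter) shows that filling this position with chloro in place of hydrogen brought a large gain, and a number 22.7 percentage points lower from compound 2 to compound 3 (beyond the scatter) shows that shifting the chloro to another position cost a modest amount. For the measured compounds named here, no measured step exchanges chloro for nitro, so the size of that exchange cannot be read from the data; since the position itself appears to matter, a modest loss or no step beyond the scatter seems the most likely outcome in this assay.

Compound 4 is therefore expected to give about 50%, within 25% to 72%. This estimate corresponds to a step of a number 12.7 percentage points lower from compound 2 to compound 4 (beyond the scatter).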

Compound 4, a percentage reported as inhibition, in the whole organism at one dose (the size of the read-out at that dose, not a potency): 4%
Estimate against measurement, compound 4: 46 percentage points above; the whole stated range lies above it.
By their numbers in this assay, from the lowest: compound 4; then compound 1; then compound 3; then compound 2.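

In this assay, the exchange of chloro for nitro on this aromatic carbon, ortho to a large group, gives a number 58.7 percentage points lower from compound 2 to compound 4 (beyond the scatter), so the gain seen with chloro does not carry over to every group placed there. Filling the position is not enough in itself: nitro gives a number 14.9 percentage points lower from compound 1 to compound 4 (beyond the scatter), whereas chloro gave a number 43.8 percentage points higher from compound 1 to compound 2 (beyond the scatter), and the two groups therefore move the read-out in opposite directions from the same unsubstituted parent. Nothing in the data given accounts for this difference.

Going by these compounds, whether an amine, a carboxylic acid or a methoxy group at this position would follow chloro or nitro remains open. Also open, on these data alone, is how nitro would behave at the position where compound 3 carries its chloro.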